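From compound 2 to compound 3: one sulfonyl exchange

The source may hold more compounds than are shown below. What is called first, only, known or untested is meant among the compounds shown, and "the series" means these compounds.

- Compound 1 (`CCCCNC(=O)C(=O)NCCCC/C=C\CCCCCCC(=O)OCCOCCOCCO`) gives 1500 nM in the test below
- Compound 2 (`CCCCCNC(=O)NCCCC/C=C\CCCCCNS(=O)(=O)c1ccccc1`) gives 3400 nM in the same test

Both numbers come from a functional assay on Coronary artery (Bos taurus) (on this read-out higher numbers stand for an effect only at larger amounts of compound and lower numbers for an effect already at smaller amounts), and compound 2 holds the higher of the two, a gap beyond the usual scatter. For the measured compounds named here, the two compounds differ in more than one place, so no measured step bears directly on the next change. Compound 3 (`CCCCCNC(=O)NCCCC/C=C\CCCCCS(=O)(=O)c1ccccc1O`) arises from compound 2 by a single exchange: (2-hydroxyphenyl)sulfonyl in place of (phenylsulfonyl)amino on a saturated chain carbon, five bonds along the chain from a double-bonded chain carbon. With compound 2 at 3400 nM as the closest reference, no step beyond the scatter is expected in this assay in either direction. The estimated step (a 1.4-fold lower number from compound 2 to compound 3 (0.13 log units; within the scatter)) is therefore small. The expected value for compound 3 is 2500 nM (estimated range 700 nM to 9000 nM).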

Compound 3, half-maximal effective concentration: 5000 nM
Compound 3: middle estimate off by 2.0-fold (0.30 log units), on the low side; the measured number falls inside the stated range.
By their numbers in this assay, from the lowest: compound 1; then compounds 2 and 3 (each within the scatter of the next).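

In this assay, the exchange at this saturated chain carbon, five bonds along the chain from a double-bonded chain carbon, gives a 1.5-fold higher number from compound 2 to compound 3 (0.17 log units; within the scatter), so this read-out does not separate the two groups. For the compounds shown here, this is the first single-place comparison, and it shows that (2-hydroxyphenyl)sulfonyl, which carries no nitrogen, can stand in place of (phenylsulfonyl)amino without a step beyond the scatter. No supporting evidence bears on this result.

Going by these compounds, the exchange alters the link to the chain and the aromatic ring in one step, so the part played by each remains open; a plain phenylsulfonyl group would be needed to separate them. On these data alone, how a carboxylic acid or an amine at this place, or a longer chain leading to it, would read in this assay also remains open.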